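The compounds below may be only part of what the source reports. "The series", "measured", "known", "first", "only" and "open" are said of these compounds alone.

Of the compounds shown here, two have numbers so far in a functional assay on DU-145 cells (Homo sapiens) for antiproliferative activity, read by propidium iodide staining, with a stated time of 96 h; a higher number here means a weaker inhibitor, a lower number a stronger inhibitor. Compound 1 `CC(O)(CS(=O)(=O)c1ccc(OC(F)(F)F)cc1)C(=O)Nc1ccc(S(F)(F)(F)(F)F)cc1` gives 39300 nM, and compound 2 `CC1(C)C(=O)N(c2ccc(C#N)cc2C(F)(F)F)C(=S)N1c1ccc(S(F)(F)(F)(F)F)cc1` gives 12700 nM. Compound 2 therefore holds the lower number of the pair, making it the stronger inhibitor of the two, and the gap lies beyond the usual scatter. These two compounds differ in more than one place, so their gap cannot be assigned to any single group.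

Compound 3 `CC1(C)C(=O)N(c2ccc([N+](=O)[O-])cc2C(F)(F)F)C(=S)N1c1ccc(S(F)(F)(F)(F)F)cc1` departs from compound 2 at one place only: nitro in place of cyano on an aromatic carbon. This is nitro in place of cyano on an aromatic carbon, meta to a trifluoromethyl group and para to a large group. Among the compounds with values here, the series contains no measured step between compounds that differ in one place, so no measured precedent exists for this exchange, and the expectation rests on the structural change alone. The expected step is a 1.1-fold lower number from compound 2 to compound 3 (0.02 log units; within the scatter), with no shift beyond the scatter and neither direction favoured. Compound 3 is estimated at 12000 nM, with an expected range of 5000 nM to 30000 nM.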

Compound 3, half-maximal inhibitory concentration: 100000 nM
Compound 3: middle estimate off by 8.3-fold (0.92 log units), on the low side; the measured number lies above the stated range.
By their numbers in this assay, from the lowest: compound 2; then compound 1; then compound 3.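

In this assay, within the data shown here, the aromatic carbon meta to a trifluoromethyl group and para to a large group proves sensitive to the group it carries: nitro in place of cyano gives a 7.9-fold higher number from compound 2 to compound 3 (0.90 log units; beyond the scatter), the first step that can be read at a single place. Among these compounds, with the step beyond the scatter, the two groups cannot be treated as interchangeable at this position on this core, and cyano is the one of the pair that goes with the lower number and the stronger inhibition. No measurement shown accounts for the size of this step, so it stands as an observation only.

As far as these compounds go, whether the loss is particular to nitro or extends to other groups at this carbon remains open, and a chlorine atom, an acetyl group or a carboxylic acid in the same place would show how narrow the preference for cyano is. Among the compounds shown here, also open is whether the same exchange gives a step of similar size on any other core, since this single pair offers only one reading of it.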